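This account rests on a few compounds, and the source may have more. Where it says the series, first, only, none or still open, it means among the compounds named here.

Measured so far in a functional assay on PC-3 cells (Homo sapiens) for inhibition, read by MTT assay, with a stated time of 72 h, tested at 1 uM; a lower number here means less inhibition of growth, a higher number more inhibition of growth at the concentration tested:
Compound 1, `COc1cc2ncnc(Nc3ccc([N+](=O)[O-])cc3)c2c(OC)c1OC`, gives 7.9%.
Compound 2, `COc1cc2ncnc(Nc3ccc(F)cc3)c2c(OC)c1OC`, gives 3.1%.
Compound 3, `COc1cc2ncnc(Nc3ccccc3[N+](=O)[O-])c2c(OC)c1OC`, gives 11.3%.

Compound 1 and compound 2 differ by one change, (fluoro in place of nitro on an aromatic carbon), and the step is a number 4.8 percentage points lower from compound 1 to compound 2 (within the scatter). Compound 3 is built from the same atoms as compound 1, joined differently; the difference between the two cores is not broken down here. The number for compound 3 lies within the scatter of both compound 1 and compound 2, so no order among the three is drawn.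

Compound 4, `COc1cc2ncnc(Nc3ccccc3F)c2c(OC)c1OC`, is not yet measured in this assay. It stands to compound 3 as compound 2 stands to compound 1: fluoro in place of nitro on an aromatic carbon. The place lines are not identical: in compound 1 the group sits para to a large group, in compound 3 ortho to a large group, so this is the same kind of change rather than the same change. For compound 4 a step near the earlier one is expected, a number 4.8 percentage points lower from compound 3 to compound 4 (within the scatter), because a number 4.8 percentage points lower from compound 1 to compound 2 (within the scatter) was within the scatter. Compound 4 in this assay is therefore estimated at 6.5%.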

Compound 4, percent growth inhibition at one concentration: 0.9%
Compound 4: the middle estimate sits 5.6 percentage points above what was measured; the range from low to high includes it.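

Set side by side in this assay, the two steps for fluoro in place of nitro do not differ: the same change on two cores in this assay, a number 4.8 percentage points lower (within the scatter) from compound 1 to compound 2 and a number 10.4 percentage points lower (beyond the scatter) from compound 3 to compound 4, 5.6 percentage points apart, within the scatter of two such steps. On the core of compound 3 the step is a number 10.4 percentage points lower from compound 3 to compound 4 (beyond the scatter), while the step on the core of compound 1 stays within the scatter, so the pairs allow the change to be carried from one core to the other but do not show that it has the same size on both. The fluoro compounds themselves cannot be told apart, with 2-fluorophenyl in place of 4-fluorophenyl giving a number 2.2 percentage points lower from compound 2 to compound 4 (within the scatter), so these numbers show no effect of where the fluoro sits.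

Open, from the compounds shown here alone, is how other groups at these places would read in this assay, for example an amine, a carboxylic acid or a nitrile. Also open, going by these compounds, is whether the same change would give a comparable step on a core carrying other groups than the methoxy groups shared here.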